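Changing the Sulfonyl Aryl Group of Compound 3

A few compounds are considered here, and "the series" means these few. Any claim that something is new, unique, unknown or untested is made for them only; others in the source may bear on it.

The set holds three measured compounds: compound 1 `COc1ccc(-c2[nH]c3cc(OC)cc(OC)c3c(=O)c2I)cc1`, compound 2 `COC(=O)c1cc(=O)c2c(OC)cc(OC)cc2[nH]1` and compound 3 `COc1ccc(-c2cc(=O)c3c(OC)cc(OC)cc3n2S(=O)(=O)c2ccc(C=O)cc2)cc1`, each tested in a functional assay on HepG2 cells (Homo sapiens) for antiproliferative activity, with a stated time of 72 h; a lower number here means that less compound is needed, a higher number that more compound is needed for the effect. Compound 1 gives only a limit in this assay, > 86200 nM. Compound 2 also gives only a limit, > 34400 nM. Compound 3 likewise stands at a limit, > 34400 nM, so no number is known for it. Two of the three values sit at the limit of > 34400 nM in this assay, at which 2 of the 3 values shown sit, and one at the limit of > 86200 nM in this assay, at which 1 of the 3 values shown sits, so none of the three compounds can be ordered against another.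

The unmeasured compound 4 `COc1ccc(-c2cc(=O)c3c(OC)cc(OC)cc3n2S(=O)(=O)c2cc(Cl)cc(Cl)c2O)cc1` differs from compound 3 in a single place: 3,5-dichloro-2-hydroxyphenyl in place of 4-formylphenyl on a sulfonyl sulfur. For the measured compounds named here, no step between measured compounds is available, so the effect of this change in this assay cannot be read from anything measured here. Because compound 3 reaches only the limit > 34400 nM, there is no number from which a shift could be gauged, and the expected step from compound 3 to compound 4 is none beyond the scatter, in either direction.

Compound 4 is therefore expected to give about 40000 nM, within a range from 8000 nM to 120000 nM, most probably reported again as a limit. That expectation corresponds to a step that the limit leaves unreadable from compound 3 to compound 4.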

Compound 4, half-maximal effective concentration: > 37900 nM
Compound 4 was reported as a limit; the forecaster's own chance of this, stated with the estimate: 70%; the middle value lies beyond the limit too.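

Compound 4 stands only at a limit in this assay, > 37900 nM. Compound 3 also stands only at a limit, > 34400 nM, so no step can be read between compound 3 and compound 4. The compounds shown leave open what placing 3,5-dichloro-2-hydroxyphenyl in place of 4-formylphenyl on a sulfonyl sulfur does to the effect in this assay.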